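From Isobutoxy to Allyloxy on a Shared Core

A few compounds are considered here, and "the series" means these few. Any claim that something is new, unique, unknown or untested is made for them only; others in the source may bear on it.

Of the compounds shown here, three sharing one core have been measured in a functional assay on the whole organism (strain Sprague-Dawley) for inhibition, with Rattus norvegicus as the target, with a stated time of 10 min; a lower number here means that less compound is needed, a higher number that more compound is needed for the effect. Compound 1 `CCOC(=O)c1cnc(-c2ccccc2F)[nH]c1=O`, carrying fluoro, returns only a limit, > 10 mg/kg. Compound 2 `CCCCOc1ccccc1-c1ncc(C(=O)OCC)c(=O)[nH]1`, carrying butoxy, gives 0.5 mg/kg. Compound 3 `CCOC(=O)c1cnc(-c2ccccc2OCC(C)C)[nH]c1=O`, carrying isobutoxy, gives 3 mg/kg. Compound 3 therefore has the higher of the two actual numbers, and compound 2 is its nearest neighbour.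

Compound 4 `C=CCOc1ccccc1-c1ncc(C(=O)OCC)c(=O)[nH]1` differs from compound 3 by vinyl in place of isopropyl on a saturated chain carbon bound to an oxygen on an aromatic ring. The most relevant measured change is isopropyl in place of propyl at that same place, which gave a 6.0-fold higher number from compound 2 to compound 3 (0.78 log units; beyond the scatter). The fluoro replacements, an at least 20-fold lower number from compound 1 to compound 2 (1.30 log units; beyond the scatter) and an at least 3.3-fold lower number from compound 1 to compound 3 (0.52 log units; beyond the scatter), bear on it only loosely. Compound 4 also loses the isopropyl, but vinyl is not propyl, so only part of that gap is expected to be recovered. The expected step, toward a lower number, is a 2.5-fold lower number from compound 3 to compound 4 (0.40 log units; beyond the scatter). The estimate for compound 4 is 1.2 mg/kg, with an expected range of 0.4 mg/kg to 4 mg/kg.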

Compound 4, dose for 50% inhibition: 0.5 mg/kg
Compound 4: the middle estimate sits 2.4-fold (0.38 log units) above what was measured; the measured number falls inside the stated range.
By their numbers in this assay, from the lowest: compounds 2 and 4 (each within the scatter of the next); then compound 3. At a limit, above all of these: compound 1.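

In this assay, the isobutoxy of compound 3 is not the limit of what this position allows: a 6.0-fold lower number from compound 3 to compound 4 (0.78 log units; beyond the scatter). The low number is also not tied to the butoxy of compound 2, since no change at the digits printed from compound 2 to compound 4 (within the scatter), so two different unbranched chains on this oxygen now read alike, with the branched isobutoxy standing apart. Compound 1 is held only at a limit, so an at least 20-fold lower number from compound 1 to compound 4 (1.30 log units; beyond the scatter) gives a bound rather than a size: the limit of > 10 mg/kg in this assay, at which 1 of the 4 values shown sits.

The compounds shown leave open whether the double bond of the allyloxy contributes anything, since a saturated propoxy would be the direct comparison. From the compounds shown here alone, how far this position tolerates change also remains open, for example a longer chain such as hexyloxy, or a chain ending in an amine or a carboxylic acid.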